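A few compounds are considered here, and "the series" means these few. Any claim that something is new, unique, unknown or untested is made for them only; others in the source may bear on it.

- Compound 1 `COc1ccccc1-c1ccc2ncn(-c3cc(OC)c(OC)c(OC)c3)c2c1`: 5050 nM
- Compound 2 `COc1cc(-n2cnc3ccc(-c4ccc(C)cc4F)cc32)cc(OC)c1OC`: 5650 nM

Both numbers come from a functional assay on SGC-7901 cells (Homo sapiens) for antiproliferative activity, read by MTT assay, with a stated time of 72 h (a higher number here means a weaker inhibitor, a lower number a stronger inhibitor), and cannot be told apart: a 1.1-fold higher number from compound 1 to compound 2 (0.05 log units; within the scatter) lies within the usual scatter, so compound 1 stands level with compound 2. Compound 3 `COc1cc(-n2cnc3ccc(-c4cc(F)ccc4F)cc32)cc(OC)c1OC` has not yet been measured. It differs from compound 1 by 2,5-difluorophenyl in place of 2-methoxyphenyl on an aromatic carbon (the counted change: 2,5-difluorophenyl in place of 2-methoxyphenyl on an aromatic carbon). Among the compounds with values here, only one measured step bears on this swap. Putting 2-fluoro-4-methylphenyl in place of the same 2-methoxyphenyl gave a 1.1-fold higher number from compound 1 to compound 2 (0.05 log units; within the scatter) and so stayed within the scatter. A single step is thin evidence, which calls for a wide range. No step beyond the scatter is expected in this assay and the estimate is (expected: a 1.1-fold higher number from compound 1 to compound 3 (0.04 log units; within the scatter)). For compound 3 the estimated value is 5500 nM (expected range 2500 nM to 12000 nM).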

Compound 3, half-maximal inhibitory concentration: 6590 nM
The estimate for compound 3 lay 1.2-fold (0.08 log units) below the measured number; the range from low to high includes it.
By their numbers in this assay, from the lowest: compounds 1, 2 and 3 (each within the scatter of the next).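

In this assay, a second replacement of the 2-methoxyphenyl again stays within the scatter: putting 2,5-difluorophenyl in its place gives a 1.3-fold higher number from compound 1 to compound 3 (0.12 log units; within the scatter) and so cannot be told apart from the starting compound. The entering group has no oxygen and no hydrogen-bond acceptor, so the acceptor counted on the 2-methoxyphenyl is not required to keep the number at this level on the shared core, and swapping 2-fluoro-4-methylphenyl for 2,5-difluorophenyl gives a 1.2-fold higher number from compound 2 to compound 3 (0.07 log units; within the scatter) with no readable change either. No measurement at hand explains why these three compounds sit so close.

From the compounds shown here alone, all three groups at this position are substituted phenyl rings, so what an amine, a carboxylic acid or a longer chain would do there remains open. Also open, going by these compounds, is whether any change at this position can move the number beyond the scatter, in either direction.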